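Swapping a benzyl amide for a piperidine amide

This account rests on a few compounds, and the source may have more. Where it says the series, first, only, none or still open, it means among the compounds named here.

Going by the values given here, compound 2 `CN(Cc1cccc(F)c1)C(=O)c1sc(-c2ccc(S(C)(=O)=O)c([N+](=O)[O-])c2)nc1C(F)(F)F` gives 2800 nM in a functional assay for antagonist activity at thyroid hormone receptor beta (Homo sapiens), read by fluorescence polarization, with a stated time of 3 h (on this read-out higher numbers stand for weaker inhibition and lower numbers for stronger inhibition), the lowest of the three numbers measured so far; compound 1 `CN(Cc1cccc(F)c1)C(=O)c1cnc(-c2ccc(S(C)(=O)=O)c([N+](=O)[O-])c2)s1` gives 8500 nM and compound 3 `Cc1nc(-c2ccc(S(C)(=O)=O)c([N+](=O)[O-])c2)sc1C(=O)N1CC2(C)CC1CC(C)(C)C2` gives 7100 nM. Compound 4 `CS(=O)(=O)c1ccc(-c2nc(C(F)(F)F)c(C(=O)N3CCCCC3)s2)cc1[N+](=O)[O-]` differs from compound 2 by piperidin-1-yl in place of (3-fluorobenzyl)(methyl)amino on a carbonyl carbon. Among the compounds with values here, the only single-point step measured, a 3.0-fold lower number from compound 1 to compound 2 (0.48 log units; beyond the scatter), concerns the trifluoromethyl group and not the amide, so no measured step bears directly on this change. Compound 3 carries a different amine on the carbonyl together with a methyl in place of the trifluoromethyl, and its higher number shows only that other amides have given weaker inhibition. Compound 4 is therefore expected to weaken, an estimated 2.9-fold higher number from compound 2 to compound 4 (0.46 log units; beyond the scatter). In this assay compound 4 is expected at 8000 nM, within a range of 2500 nM to 25000 nM.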

Compound 4, half-maximal inhibitory concentration in the thyroid hormone receptor beta assay: 660 nM
The estimate for compound 4 lay 12-fold (1.08 log units) above the measured number; measured number below the stated range.
By their numbers in the thyroid hormone receptor beta assay, from the lowest: compound 4; then compound 2; then compounds 3 and 1 (each within the scatter of the next).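

In the thyroid hormone receptor beta assay, compound 2 gives 2800 nM and compound 4 gives 660 nM, and piperidin-1-yl gives a 4.2-fold lower number from compound 2 to compound 4 (0.63 log units; beyond the scatter), so the aromatic ring of (3-fluorobenzyl)(methyl)amino is not required on this carbonyl carbon for inhibition. In a physicochemical assay for solubility, in phosphate buffer, at pH 7.4 (on this read-out lower numbers stand for lower solubility and higher numbers for higher solubility), compound 2 gives 1200 nM and compound 4 gives 1600 nM, and the same change gives a 1.3-fold higher number from compound 2 to compound 4 (0.12 log units; within the scatter), so no difference in solubility can be claimed. Nothing at hand explains the stronger inhibition. Going by these compounds, whether a pyrrolidine or a morpholine on the same carbonyl carbon would keep this gain remains open. So does whether removing the trifluoromethyl group would have the same effect on the piperidine amide.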